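Thienopyridine amides: benzyl-to-thiourea swap at the ring nitrogen

The source may report more compounds than this note shows. Statements on the series, on what has been measured and on what is new or still open speak of the compounds shown alone.

Going by the values given here, in a functional assay on HeLa cells (Homo sapiens) for antiproliferative activity, with a stated time of 24 h (a lower number here means a stronger inhibitor, a higher number a weaker inhibitor), compound 2 `NC(=O)c1c(NC(=O)c2ccccc2Cl)sc2c1CCN(Cc1cc(Cl)cc(Cl)c1)C2` gives 19600 nM, the lowest of the two numbers so far; compound 1 `NC(=O)c1c(NC(=O)c2ccccc2Cl)sc2c1CCN(Cc1ccc([N+](=O)[O-])cc1)C2` gives 46100 nM, and the step of a 2.4-fold lower number from compound 1 to compound 2 (0.37 log units; beyond the scatter) is modest. Compound 3 `NC(=O)c1c(NC(=O)c2ccccc2Cl)sc2c1CCN(C(=S)Nc1ccccc1)C2` carries a group of 9 heavy atoms (7 carbon, 1 nitrogen, 1 sulfur; one six-membered aromatic ring of carbon only) in place of a group of 9 heavy atoms (7 carbon, 2 chlorine; one six-membered aromatic ring of carbon only), on an amine nitrogen in a ring. Among the compounds with values here, no measured step changes the group on this nitrogen beyond a substituent swap on the aryl ring, so the one step of a 2.4-fold lower number from compound 1 to compound 2 (0.37 log units; beyond the scatter) bears only loosely on it. Compound 3 is therefore expected to stay close to compound 2 in this assay, with wide uncertainty, the estimated step being a 1.5-fold higher number from compound 2 to compound 3 (0.18 log units; within the scatter). For compound 3 the estimate in this assay is 30000 nM, within 8000 nM to 100000 nM.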

Compound 3, half-maximal inhibitory concentration: 46700 nM
Beside the measured number, compound 3's estimate is 1.6-fold (0.19 log units) below it, and the stated range covers the measured number.
By their numbers in this assay, from the lowest: compound 2; then compounds 1 and 3 (each within the scatter of the next).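

Notes on the group on the amine nitrogen in a ring: replacing the 3,5-dichlorobenzyl group with the thiourea group gives a 2.4-fold higher number from compound 2 to compound 3 (0.38 log units; beyond the scatter) in this assay, the first reading of a change beyond the aryl substituent. Against the 4-nitrophenyl-bearing benzyl group, the same thiourea gives a 1.0-fold higher number from compound 1 to compound 3 (0.01 log units; within the scatter), so here the two groups cannot be told apart, and the dichlorobenzyl of compound 2 keeps the lowest number. No measured evidence on the cause of either step is available.

Open, as far as these compounds go, is whether a simple acetyl group or a longer alkyl chain on this nitrogen would behave like the thiourea or the benzyl groups. Also open, from the compounds shown here alone, is whether chlorine atoms on the phenyl ring of the thiourea would lower the number as they do on the benzyl group.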